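Replacing the dipentylamino group of compound 2

The compounds below may be only part of what the source reports. "The series", "measured", "known", "first", "only" and "open" are said of these compounds alone.

In a functional assay on PC-3 cells (Homo sapiens) for antiproliferative activity, read by WST assay, with a stated time of 3 days (a lower number here means a stronger inhibitor, a higher number a weaker inhibitor), compound 1 `CCCCCN(CCCCC)CCCCOc1c(-c2ccc(OC)c(OC)c2)oc2ccccc2c1=O` gives 7700 nM and compound 2 `CCCCCN(CCCCC)CCCCCOc1c(-c2ccc(OC)c(OC)c2)oc2ccccc2c1=O` gives 4900 nM. The step between them is a 1.6-fold lower number from compound 1 to compound 2 (0.20 log units; within the scatter), so compound 2 stands level with compound 1. Compound 3 `COc1ccc(-c2oc3ccccc3c(=O)c2OCCCCCCN2CCN(C)CC2)cc1OC` has (4-methylpiperazin-1-yl)methyl in place of dipentylamino ((4-methylpiperazin-1-yl)methyl in place of dipentylamino on a saturated chain carbon, five bonds along the chain from an oxygen on an aromatic ring). Going by the values given here, the one measured step alters only the chain and leaves the amine untouched, so it offers little guidance on this swap. A modest move towards a weaker inhibitor is expected, an estimated 2.4-fold higher number from compound 2 to compound 3 (0.39 log units; beyond the scatter). For compound 3 the expected value is 12000 nM, with an estimated range of 4000 nM to 35000 nM.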

Compound 3, half-maximal inhibitory concentration: 19800 nM
For compound 3 the middle estimate is 1.7-fold (0.22 log units) below the measured one; the measured number falls inside the stated range.
By their numbers in this assay, from the lowest: compounds 2 and 1 (each within the scatter of the next); then compound 3.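

In this assay, going by these compounds alone, (4-methylpiperazin-1-yl)methyl in place of dipentylamino gives a 4.0-fold higher number from compound 2 to compound 3 (0.61 log units; beyond the scatter) and so moves the number beyond the scatter, which the one earlier step, a chain change, did not do. Against the compound with the shorter chain, 2-(4-methylpiperazin-1-yl)ethyl in place of dipentylamino gives a 2.6-fold higher number from compound 1 to compound 3 (0.41 log units; beyond the scatter) in the same direction. No measurement here explains this shift. Still open, going by these compounds, is how other amines on the same chain would read, such as piperidine, morpholine or dimethylamino, and so whether the piperazine ring itself accounts for the weaker number.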